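Chloro on the pendant phenyl of compound 1

The source may report more compounds than this note shows. Statements on the series, on what has been measured and on what is new or still open speak of the compounds shown alone.

Three members of the series have numbers in a functional assay on UO-31 cells (Homo sapiens) for inhibition; on this read-out lower numbers stand for stronger inhibition of growth and higher numbers for weaker inhibition of growth. Compound 1 `COc1cc(/C=C/C(=O)c2cccc(-n3cc(-c4ccccc4)[nH]c3=O)c2)ccc1O` gives 2180 nM, compound 2 `COc1cc(/C=C/C(=O)c2cccc(-n3cc(-c4ccccc4)[nH]c3=O)c2)cc(OC)c1OC` gives 1510 nM, and compound 3 `COc1cc(/C=C/C(=O)c2cccc(-n3cc(-c4cc(OC)c(OC)c(OC)c4)[nH]c3=O)c2)cc(OC)c1OC` gives 960 nM. Compound 1 holds the highest of the three numbers; its gap to compound 2 lies within the scatter, while its gap to compound 3 lies beyond it. Going by the values given here, the one step between neighbours that differ in a single place, a 1.6-fold lower number from compound 2 to compound 3 (0.20 log units; within the scatter), sits within the scatter.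

Compound 4 `COc1cc(/C=C/C(=O)c2cccc(-n3cc(-c4ccc(Cl)cc4)[nH]c3=O)c2)ccc1O` is not yet measured. It differs from compound 1 by chloro in place of hydrogen on an aromatic carbon. Among the compounds with values here, no measured step adds a chloro, so the only comparison at hand is the step from compound 2 to compound 3, which altered the same pendant ring and stayed within the scatter. On that basis no step beyond the scatter is expected in this assay for the change from compound 1 to compound 4, in either direction.

Compound 4 is therefore estimated at 2000 nM, with a range from 900 nM to 4500 nM, which means an expected step of a 1.1-fold lower number from compound 1 to compound 4 (0.04 log units; within the scatter).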

Compound 4, concentration for 50% growth inhibition: 1670 nM
Compound 4: the middle estimate sits 1.2-fold (0.08 log units) above what was measured; measured number inside the range.
By their numbers in this assay, from the lowest: compounds 3, 2, 4 and 1 (each within the scatter of the next, the first and the last beyond it).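

In this assay, going by these compounds alone, chloro in place of hydrogen on an aromatic carbon, para to a large group, gives a 1.3-fold lower number from compound 1 to compound 4 (0.12 log units; within the scatter), which is the first direct reading of a single-atom change at this position of the pendant phenyl. Together with a 1.6-fold lower number from compound 2 to compound 3 (0.20 log units; within the scatter), this means that both changes to the pendant ring shown so far, phenyl to 4-chlorophenyl and phenyl to 3,4,5-trimethoxyphenyl, stay within the scatter, although they were read on different partners at the other end of the molecule. No independent measurement accompanies these numbers, so nothing can be said about what lies behind the size of the chloro step.

From the compounds shown here alone, whether this position stays as flat with other kinds of group remains open, for example an amine, a carboxylic acid or a longer alkoxy chain in place of the chloro. Also open, going by these compounds, is whether the chloro step would read the same with the 3,4,5-trimethoxyphenyl enone end of compound 2 in place of the hydroxy-methoxy-substituted ring of compound 1.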